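The source may hold more compounds than are shown below. What is called first, only, known or untested is meant among the compounds shown, and "the series" means these compounds.

Going by the values given here, in an in vitro ADME assay on microsomes from liver (Homo sapiens) for metabolic stability (a higher number here means that the compound lasts longer, a lower number that the compound disappears faster), compound 3 `NC(=O)COc1ccc2c(c1)S(=O)(=O)N=C(c1c(O)c(-c3cccs3)nn(CC3CCC3)c1=O)N2` gives 0.367 h, the second highest of the three numbers measured so far. In this assay compound 2 `CC(C)(F)CCn1nc(-c2cccs2)c(O)c(C2=NS(=O)(=O)c3cc(OCC(N)=O)ccc3N2)c1=O` gives 0.65 h and compound 1 `NC(=O)COc1ccc2c(c1)S(=O)(=O)N=C(c1c(O)c(-c3cccs3)nn(CCC3CC3)c1=O)N2` gives 0.2 h, and both lie within the scatter of compound 3. Compound 4 `NC(=O)COc1ccc2c(c1)S(=O)(=O)N=C(c1c(O)c(-c3cccs3)nn(CC3CCCCC3)c1=O)N2` differs from compound 3 by cyclohexyl in place of cyclobutyl on a saturated chain carbon bound to an aromatic nitrogen. Among the compounds with values here, two measured steps touch the same place: a 1.8-fold higher number from compound 1 to compound 3 (0.26 log units; within the scatter) and a 1.8-fold lower number from compound 2 to compound 3 (0.25 log units; within the scatter), neither beyond the scatter. Only a 3.3-fold higher number from compound 1 to compound 2 (0.51 log units; beyond the scatter) was larger, and that change sits two bonds along the chain from the aromatic nitrogen. Within the data shown here, with no step at this place beyond the scatter, the cyclohexyl in place of the cyclobutyl is expected to give a 1.1-fold higher number from compound 3 to compound 4 (0.04 log units; within the scatter), with no clear direction. Compound 4 is therefore estimated at 0.4 h, within the range 0.15 h to 1 h.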

Compound 4, half-life: > 1 h
Compound 4 was reported as a limit (the forecaster's own chance of this, stated with the estimate: 5%); at least 2.5-fold (0.39 log units) between middle value and limit.
By their numbers in this assay, from the lowest: compounds 1, 3 and 2 (each within the scatter of the next, the first and the last beyond it). At a limit, above all of these: compound 4.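

In this assay compound 4 gives > 1 h, which is a limit of the assay and not a number. Going by these compounds alone, the place on the saturated chain carbon bound to an aromatic nitrogen, where no earlier step passed the scatter, now shows an at least 2.7-fold higher number from compound 3 to compound 4 (0.43 log units; beyond the scatter) and an at least 5.0-fold higher number from compound 1 to compound 4 (0.69 log units; beyond the scatter). Against the chain of compound 2 the order stays unsettled, with an at least 1.5-fold higher number from compound 2 to compound 4 (0.18 log units; that floor lies within the scatter).

The compounds shown leave open how far the true value of compound 4 lies past its limit. They also leave open whether cyclopentyl or tetrahydropyranyl in the same place would give a similar number.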